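Removing a Ring Methyl Group: Effect on Microsomal Clearance

The source may report more compounds than this note shows. Statements on the series, on what has been measured and on what is new or still open speak of the compounds shown alone.

Four compounds sharing a four-membered non-aromatic ring of carbon only are compared here. Compound 1 `C[C@]1(O)C[C@](c2ccnc(C(F)(F)F)c2)([C@H](O)c2ccccn2)C1` was measured in an ADME assay on liver for metabolic stability, with Liver microsome (Rattus norvegicus) as the target, read by LC-MS, using microsomes, with a stated time of 5 h (on this read-out higher numbers stand for fast clearance and lower numbers for slow clearance), where compound 1 gives 83.3 mL/min/kg. Compound 2 `O[C@H](c1ccccn1)[C@]1(c2ccnc(C(F)(F)F)c2)C[C@H](O)C1` differs from compound 1 by hydrogen in place of methyl on a saturated ring carbon and in this assay compound 2 gives 50 mL/min/kg. The step of a 1.7-fold lower number from compound 1 to compound 2 (0.22 log units; within the scatter) is therefore small. Compound 3 `C[C@]1(O)C[C@@](c2cc(C(F)(F)F)ccn2)([C@H](O)c2ccccn2)C1` carries a different core; the difference between the core of compound 1 and the core of compound 3 is not broken down here. In this assay compound 3 gives 117 mL/min/kg, a value that sits close to that of compound 1, while compound 2 shows a clearly lower number than compound 3.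

Compound 4 `O[C@H](c1ccccn1)[C@]1(c2cc(C(F)(F)F)ccn2)C[C@@H](O)C1` is the unmeasured member of the set. It differs from compound 3 by hydrogen in place of methyl on a saturated ring carbon, the same change as that from compound 1 to compound 2, made on the core of compound 3 rather than the core of compound 1. Because the earlier step of a 1.7-fold lower number from compound 1 to compound 2 (0.22 log units; within the scatter) stayed within the usual scatter, the step from compound 3 to compound 4 is expected to be of similar size, a 1.7-fold lower number from compound 3 to compound 4 (0.22 log units; within the scatter). On that basis compound 4 is estimated to give 70 mL/min/kg in this assay, with a plausible range from 40 mL/min/kg to 120 mL/min/kg, the measurement itself still to come.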

Compound 4, clearance: 50 mL/min/kg
For compound 4 the middle estimate is 1.4-fold (0.15 log units) above the measured one; measured number inside the range.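

On the core of compound 3, hydrogen in place of methyl on a saturated ring carbon gives, in this assay, a 2.3-fold lower number from compound 3 to compound 4 (0.37 log units; beyond the scatter), a modest step. Going by these compounds alone, the number falls on both cores, although only this second step lies beyond the scatter, and the two steps cannot be told apart in size: the same change on two cores in this assay, a 1.7-fold lower number (0.22 log units; within the scatter) from compound 1 to compound 2 and a 2.3-fold lower number (0.37 log units; beyond the scatter) from compound 3 to compound 4, 1.4-fold (0.15 log units) apart, within the scatter of two such steps. This agreement suggests that the change carries from one of these cores to the other, but it rests on a single pair for each core in one assay, so it sets no rule for other cores and does not explain why the number falls.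

The compounds shown leave open whether a larger or different replacement on that ring carbon, such as an ethyl group or a fluorine in place of the methyl, would give a step of similar size. They also leave open how the same change would behave if an amine took the place of the ring hydroxy group, or if a nitrile took the place of the trifluoromethyl group on either core.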